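This account rests on a few compounds, and the source may have more. Where it says the series, first, only, none or still open, it means among the compounds named here.

Measured compounds in a functional assay on MCF7 cells (Homo sapiens) for cytotoxicity, read by sulforhodamine B assay, with a stated time of 48 h; a higher number here means a weaker inhibitor, a lower number a stronger inhibitor:
- compound 1, `C=CCOc1ccc(Br)cc1C(=O)c1cccnc1`: 92000 nM
- compound 2, `O=C(c1cccnc1)c1cc(Br)ccc1O`: 53500 nM

Going by the values given here, compound 1 stands highest of the two numbers so far, with compound 2 the nearest; the two values sit within the scatter of each other, so no order between them can be read. Among the compounds with values here, the only measured step in this assay , a 1.7-fold lower number from compound 1 to compound 2 (0.24 log units; within the scatter), changes the group on the ring oxygen and leaves the bromo untouched.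

Compound 3, `C=CCOc1ccccc1C(=O)c1cccnc1`, is not yet measured. It differs from compound 1 in one place: hydrogen in place of bromo on an aromatic carbon. Within the data shown here, no measured pair removes the bromo, so no step here speaks directly to this change. Among the measured compounds shown here, the one step on record, from compound 1 to compound 2, shows that a change on the same core left the number within the scatter, which gives no hint of a large shift for the step to compound 3 either.

The number for compound 3 in this assay is therefore expected to stay close to that of compound 1, with a 1.2-fold higher number from compound 1 to compound 3 (0.08 log units; within the scatter) expected to fall within the scatter. Compound 3 is estimated at 110000 nM, ranging from 45000 nM to 270000 nM.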

Compound 3, half-maximal inhibitory concentration: > 100000 nM
Compound 3 was reported as a limit; the forecaster's own chance of this, stated with the estimate: 25%; the middle value does not contradict the limit.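

Compound 3 gives > 100000 nM in this assay, which is a limit of the assay and not a number. For hydrogen in place of bromo on an aromatic carbon, para to an allyloxy group, the step is an at least 1.0-fold higher number from compound 1 to compound 3 (0.03 log units; that floor lies within the scatter); this is the only change shown at this position, and it brings no lower number, while the true size of any rise stays unknown. The reading for this change therefore ends at a limit rather than at a measured value: the limit of > 100000 nM in this assay, at which 1 of the 3 values shown sits.

Still open, on these data alone, is whether a different group on this aromatic carbon, such as an amine or a carboxylic acid, would give a number clearly apart from that of compound 1. Also open is how the bromo and the allyloxy group act together, since the compounds shown do not pair hydrogen at this position with a free hydroxyl on the ring, and no longer chain on the ring oxygen appears alongside either the bromo or the hydrogen.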